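The source may report more compounds than this note shows. Statements on the series, on what has been measured and on what is new or still open speak of the compounds shown alone.

Measured so far:
compound 1 `COc1ccc(-c2nc(N)c3nc(-c4ccccc4)sc3n2)cc1`: 225 nM
compound 2 `N#Cc1cccc(-c2nc(N)c3nc(-c4ccccc4)sc3n2)c1`: 594 nM

Both compounds share the same core and differ only in the aryl group attached to it. In an assay on CHO cells for displacement of a labelled ligand from adenosine receptor A1 (Homo sapiens), read by scintillation counting, with a stated time of 3 h (a higher number here means a weaker inhibitor, a lower number a stronger inhibitor), compound 1 gives 225 nM, and compound 2 gives 594 nM. Among the measured compounds shown here, the one measured step, a 2.6-fold higher number from compound 1 to compound 2 (0.42 log units; beyond the scatter), is modest but beyond the scatter. Compound 2 thus stands with the higher of the two numbers in this assay.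

Compound 3 `Cc1ccc(-c2nc(N)c3nc(-c4ccccc4)sc3n2)o1` is not yet measured. The change from compound 2 is 5-methylfuran-2-yl in place of 3-cyanophenyl on an aromatic carbon. For the measured compounds named here, only the step from compound 1 to compound 2 bears on this, and it concerns a different pair of groups at the same position, so it shows no more than that swapping the aryl group at this position moves the number by a modest amount. Nothing measured speaks directly for or against 5-methylfuran-2-yl. The expected direction is therefore uncertain, and the step of a 2.1-fold lower number from compound 2 to compound 3 (0.33 log units; beyond the scatter) is estimated as modest, most likely toward a lower number, given that compound 2 holds the higher of the two numbers. Compound 3 is expected to give about 280 nM in this assay, with a range from 80 nM to 1000 nM.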

Compound 3, inhibition constant: 28.9 nM
Beside the measured number, compound 3's estimate is 9.7-fold (0.99 log units) above it; the whole stated range lies above it.
By their numbers in this assay, from the lowest: compound 3; then compound 1; then compound 2.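

In this assay, among the compounds shown here, the aryl position on the shared core turns out to hold a far larger range than the one earlier step suggested: against a 2.6-fold higher number from compound 1 to compound 2 (0.42 log units; beyond the scatter), the change to 5-methylfuran-2-yl gives a 21-fold lower number from compound 2 to compound 3 (1.31 log units; beyond the scatter). The same group in place of 4-methoxyphenyl gives a 7.8-fold lower number from compound 1 to compound 3 (0.89 log units; beyond the scatter), so among these three compounds the one five-membered aromatic ring with 1 hetero atom gives the lowest number, below both six-membered aromatic rings of carbon only, and both steps lie beyond the scatter. No measurement at hand accounts for this drop.

The compounds shown leave open whether the drop belongs to the furan ring itself or to its methyl group, a question that furan-2-yl without the methyl, or the same ring carrying an ethyl group or a longer chain in its place, would address. Also open, from the compounds shown here alone, is how the position responds to a furan ring bearing an amine or a carboxylic acid instead of the methyl, and whether the phenyl group elsewhere on the shared core has any bearing on the size of these steps.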